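This account rests on a few compounds, and the source may have more. Where it says the series, first, only, none or still open, it means among the compounds named here.

Compound 1, `CCOCCn1c(N2CCN(C)CC2)nc2ccccc21`: 10 nM
Compound 2, `CN1CCN(c2nc3ccccc3[nH]2)CC1`: > 3000 nM (a limit)
Compound 3, `CCCCOCCn1c(N2CCN(C)CC2)nc2ccccc21`: 38 nM

The three measured compounds share one core and differ only in the group carried on an aromatic nitrogen. In a functional assay on ileum for inhibition of histamine H1 receptor (Cavia porcellus) (on this read-out lower numbers stand for stronger inhibition and higher numbers for weaker inhibition), compound 1 gives 10 nM. For compound 2 this assay reports only a limit, > 3000 nM. Compound 3 gives 38 nM in this assay, which is the higher of the two numbers obtained; its nearest neighbour is compound 1, and that gap, a 3.8-fold higher number from compound 1 to compound 3 (0.58 log units; beyond the scatter), lies beyond the scatter. Taking the chain away altogether costs far more: an at least 300-fold higher number from compound 1 to compound 2 (2.47 log units; beyond the scatter), and in the other direction an at least 78-fold lower number from compound 2 to compound 3 (1.89 log units; beyond the scatter).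

Compound 4, `CCCCCCCn1c(N2CCN(C)CC2)nc2ccccc21`, is not yet measured. Its difference from compound 3 is this: pentyl in place of butoxy on a saturated chain carbon, two bonds along the chain from an aromatic nitrogen. Among the measured compounds shown here, no measured step exchanges an oxygen in the chain for a carbon; the measured steps concern only whether the chain is present and how long it is. The chain-length step a 3.8-fold higher number from compound 1 to compound 3 (0.58 log units; beyond the scatter) was modest, so a step of comparable or smaller size is expected here, with no clear direction. Compound 4 is therefore expected to show a 1.6-fold higher number from compound 3 to compound 4 (0.20 log units; within the scatter). The estimate for compound 4 in this assay is 60 nM, within a range from 15 nM to 250 nM.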

Compound 4, half-maximal inhibitory concentration: 150 nM
Estimate against measurement, compound 4: 2.5-fold (0.40 log units) below, within the range that was stated.
By their numbers in this assay, from the lowest: compound 1; then compound 3; then compound 4. At a limit, above all of these: compound 2.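

Among the compounds shown here, exchanging the chain oxygen for a carbon, which no earlier step covered, has a measurable effect at this position, even though butoxy and pentyl each count 5 heavy atoms: a 3.9-fold higher number from compound 3 to compound 4 (0.60 log units; beyond the scatter), and the entering pentyl has no hydrogen-bond acceptor where the leaving butoxy has one. Against the shorter ethoxy chain, the step is larger, a 15-fold higher number from compound 1 to compound 4 (1.18 log units; beyond the scatter), while the all-carbon heptyl chain still stands well clear of the unsubstituted compound, an at least 20-fold lower number from compound 2 to compound 4 (1.30 log units; beyond the scatter), which shows that a chain without oxygen retains much of the inhibition seen on this read-out. That last step is only a bound, as compound 2 is known only as a limit: the limit of > 3000 nM in this assay, at which 1 of the 4 values shown sits.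

Compound 1 and compound 4 differ in both chain length and the oxygen, so the size of that step cannot be divided between the two, and an all-carbon chain as short as butyl would be needed to compare like with like. As far as these compounds go, whether an amine or a sulfur atom in place of the chain oxygen would behave like the ether or like the heptyl chain remains open.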